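Swapping the aryl group: from chlorophenyl to methoxyphenyl

The source may hold more compounds than are shown below. What is called first, only, known or untested is meant among the compounds shown, and "the series" means these compounds.

Measured so far:
compound 1, `COc1cc(-n2cnc3ccc(-c4cc(F)ccc4F)cc32)cc(OC)c1OC`, 6420 nM
compound 2, `COc1cc(-n2cnc3ccc(-c4cccc(Cl)c4)cc32)cc(OC)c1OC`, 3120 nM
compound 3, `COc1cc(-c2ccc3ncn(-c4cc(OC)c(OC)c(OC)c4)c3c2)cc(OC)c1OC`, > 10000 nM

In a functional assay on MCF7 cells (Homo sapiens) for antiproliferative activity, read by MTT assay, with a stated time of 72 h (a lower number here means a stronger inhibitor, a higher number a weaker inhibitor), compound 2 gives the lowest of the two numbers that are actually numbers; compound 1 lies a 2.1-fold lower number from compound 1 to compound 2 (0.31 log units; beyond the scatter) behind it. Compound 3, which carries a methoxy-bearing phenyl at the same position, reaches only the limit of the limit of > 10000 nM in this assay, at which 1 of the 3 values shown sits, so it gives no number at all.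

Compound 4 is `COc1ccc(-c2ccc3ncn(-c4cc(OC)c(OC)c(OC)c4)c3c2)cc1`. It differs from compound 2 in one place: 4-methoxyphenyl in place of 3-chlorophenyl on an aromatic carbon.

Going by the values given here, only one measured step concerns this position, a 2.1-fold lower number from compound 1 to compound 2 (0.31 log units; beyond the scatter), which was modest. Among the compounds with values here, the sole other compound with methoxy groups on the pendant phenyl, compound 3, sits at the limit, which hints that a methoxy at this position does not help. For compound 4 a modest loss is therefore expected, a 1.8-fold higher number from compound 2 to compound 4 (0.25 log units; within the scatter), with the real chance that it too reaches the limit. Compound 4 is estimated at 5500 nM, between 2500 nM and 12000 nM.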

Compound 4, half-maximal inhibitory concentration: 210 nM
The estimate for compound 4 lay 26-fold (1.42 log units) above the measured number, and the stated range ends above it.
By their numbers in this assay, from the lowest: compound 4; then compound 2; then compound 1. At a limit, above all of these: compound 3.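

Going by these compounds alone, replacing 3-chlorophenyl with 4-methoxyphenyl gives a 15-fold lower number from compound 2 to compound 4 (1.17 log units; beyond the scatter) in this assay, and replacing 2,5-difluorophenyl with the same group gives a 31-fold lower number from compound 1 to compound 4 (1.49 log units; beyond the scatter); both steps are large, whereas the only earlier step at this position was modest. The aryl group at this position can therefore move the number much further than the two halogen-bearing phenyl groups showed, and a methoxy group on that phenyl is not in itself a drawback. Compound 3, which also carries a methoxy-bearing phenyl here, goes against any general methoxy benefit, and its entry is a limit rather than a number: the limit of > 10000 nM in this assay, at which 1 of the 4 values shown sits.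

The compounds shown leave open whether the gain depends on the methoxy group itself or on where it sits on the phenyl. They also leave open whether a 4-ethoxy, 4-hydroxy or 4-dimethylamino group would match 4-methoxyphenyl.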